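Vinyl for Hydrogen on the Shared Core

This account rests on a few compounds, and the source may have more. Where it says the series, first, only, none or still open, it means among the compounds named here.

Measured compounds:
compound 1 `c1ccc(-c2nc(-c3c[nH]c4ccccc34)co2)cc1` 131000 nM
compound 2 `c1ccc2c(-c3cocn3)c[nH]c2c1` 103000 nM

Of the compounds shown here, two have been tested in a functional assay on MCF7 cells (Homo sapiens) for cytotoxicity, read by MTT assay, with a stated time of 48 h; a lower number here means a stronger inhibitor, a higher number a weaker inhibitor. Compound 1 `c1ccc(-c2nc(-c3c[nH]c4ccccc34)co2)cc1` carries a phenyl group on the shared core and gives 131000 nM in this assay. Compound 2 `c1ccc2c(-c3cocn3)c[nH]c2c1` has a hydrogen in that place and gives 103000 nM. Going by the values given here, the difference between them, a 1.3-fold lower number from compound 1 to compound 2 (0.10 log units; within the scatter), is small enough to count as no real change, so compound 2 cannot be called stronger or weaker than compound 1; it simply holds the lower of the two numbers so far.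

Compound 3 `C=Cc1nc(-c2c[nH]c3ccccc23)co1` has not yet been measured. It differs from compound 2 by vinyl in place of hydrogen on an aromatic carbon. Among the compounds with values here, the only step that bears on this change is the one from compound 1 to compound 2, where swapping a phenyl for a hydrogen at the same place left the number essentially where it was. A vinyl group is smaller than phenyl, so no step beyond the scatter is expected in this assay. Compound 3 is therefore estimated at 110000 nM, within a range of 40000 nM to 300000 nM, which amounts to an expected step of a 1.1-fold higher number from compound 2 to compound 3 (0.03 log units; within the scatter).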

Compound 3, half-maximal inhibitory concentration: 103000 nM
The estimate for compound 3 lay 1.1-fold (0.03 log units) above the measured number; low and high end bracket the measured number.
By their numbers in this assay, from the lowest: compounds 2, 3 and 1 (each within the scatter of the next).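

In this assay, putting vinyl on the aromatic carbon of the five-membered ring, next to the ring nitrogen and the ring oxygen, gives no change at the digits printed from compound 2 to compound 3 (within the scatter) for the exchange of hydrogen for this group of 2 heavy atoms. Replacing phenyl with vinyl at the same place gives a 1.3-fold lower number from compound 1 to compound 3 (0.10 log units; within the scatter) and so adds a third group to the earlier comparison of phenyl with hydrogen: hydrogen, vinyl and phenyl all give numbers within the scatter of one another, so across these three compounds the number does not follow the size of the group. No data are at hand on why the number stays within the scatter across these exchanges.

Open is whether an amine, a carboxylic acid or a longer chain at this place would move the number beyond the scatter, as none of the three groups shown has moved it. These compounds also say nothing about changes elsewhere on the shared core, where a new group might behave quite differently from the groups at this one place.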